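Hydrazone aryl swap: from compound 2 to compound 3

The source may hold more compounds than are shown below. What is called first, only, known or untested is meant among the compounds shown, and "the series" means these compounds.

- compound 1 `O=C(Cc1csc2nc(-c3ccc(Br)cc3)cn12)N/N=C/c1ccccc1O` at 2510 nM
- compound 2 `O=C(Cc1csc2nc(-c3ccc(Br)cc3)cn12)N/N=C/c1ccc(O)cc1` at 21400 nM
- compound 3 `COc1cccc(OC)c1/C=N/NC(=O)Cc1csc2nc(-c3ccc(Br)cc3)cn12`, not yet measured

In a functional assay on NCI/ADR-RES cells (Homo sapiens) for inhibition, read by sulforhodamine B assay, with a stated time of 48 h (a lower number here means a stronger inhibitor of growth, a higher number a weaker inhibitor of growth), compound 2 stands highest of the two measured, at 21400 nM. The change is 2,6-dimethoxyphenyl in place of 4-hydroxyphenyl on a carbon with a double bond to nitrogen. For the measured compounds named here, only one measured step bears on it: an 8.5-fold higher number from compound 1 to compound 2 (0.93 log units; beyond the scatter), which is beyond the scatter and swaps 2-hydroxyphenyl for 4-hydroxyphenyl at the same place. One step is thin evidence, so a modest move to a lower number in this assay is expected, a 2.7-fold lower number from compound 2 to compound 3 (0.43 log units; beyond the scatter). The estimate for compound 3 is 8000 nM, with an expected range of 2000 nM to 30000 nM.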

Compound 3, concentration for 50% growth inhibition: 12900 nM
For compound 3 the middle estimate is 1.6-fold (0.21 log units) below the measured one; measured number inside the range.
By their numbers in this assay, from the lowest: compound 1; then compounds 3 and 2 (each within the scatter of the next).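

In this assay, a 1.7-fold lower number from compound 2 to compound 3 (0.22 log units; within the scatter), so 2,6-dimethoxyphenyl and 4-hydroxyphenyl on this carbon cannot be told apart, although only the latter carries a hydroxy group. Meanwhile, a 5.1-fold higher number from compound 1 to compound 3 (0.71 log units; beyond the scatter), which leaves 2-hydroxyphenyl as the only group of the three that separates from the others, so a hydroxy group on the ring does not by itself give the low number. As far as these compounds go, whether an aminophenyl or a pyridyl ring at this carbon would match compound 1 stays open. No measurement here accounts for these differences.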